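Swapping a Ring for an Alkyne Chain on a Shared Core

A few compounds are considered here, and "the series" means these few. Any claim that something is new, unique, unknown or untested is made for them only; others in the source may bear on it.

Compound 1 `CC(COC(C)(C)C)Oc1cccc2ccc(N)nc12` gives 306 nM in an assay on cells with melanin-concentrating hormone receptor 1 (Homo sapiens) as the target, read by radioligand binding; a higher number here means a weaker inhibitor, a lower number a stronger inhibitor.
Compound 2 `CC(C)C(C)Oc1cccc2ccc(N)nc12` gives 199 nM in this assay.
Compound 3 `Nc1ccc2cccc(OCC3CCOC3)c2n1` gives 115 nM in this assay.

Compound 3 shows the lowest of the three numbers, but only its gap to compound 1 lies beyond the scatter; its gap to compound 2 lies within it. Compound 4 `CCC#CCOc1cccc2ccc(N)nc12` is not yet measured and differs from compound 3 by but-1-yn-1-yl in place of oxolan-3-yl on a saturated chain carbon bound to an oxygen on an aromatic ring. Two measured steps also exchanged the chain on the oxygen on the aromatic ring: a 1.5-fold lower number from compound 1 to compound 2 (0.19 log units; within the scatter) and a 1.7-fold lower number from compound 2 to compound 3 (0.24 log units; within the scatter). Neither moved the number beyond the scatter, so for compound 4 no step beyond the scatter is expected in this assay, in either direction. Compound 4 is estimated at 150 nM, between 50 nM and 450 nM, an expected step of a 1.3-fold higher number from compound 3 to compound 4 (0.12 log units; within the scatter).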

Compound 4, half-maximal inhibitory concentration: > 2000 nM
Compound 4 was reported as a limit; the forecaster's own chance of this, stated with the estimate: 3%; middle value at least 13-fold (1.12 log units) from the limit.
By their numbers in this assay, from the lowest: compounds 3, 2 and 1 (each within the scatter of the next, the first and the last beyond it). At a limit, above all of these: compound 4.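

In this assay, earlier chain exchanges on the oxygen on an aromatic ring stayed within the scatter, but this position does not accept every chain: but-1-yn-1-yl in place of oxolan-3-yl gives an at least 17-fold higher number from compound 3 to compound 4 (1.24 log units; beyond the scatter), and pent-2-yn-1-yl in place of 1,2-dimethylpropyl gives an at least 10-fold higher number from compound 2 to compound 4 (1.00 log units; beyond the scatter). The value of compound 4, > 2000 nM, is a limit and not a number. Of the four chains shown, only the one in compound 4 holds a triple bond.

From the compounds shown here alone, whether that triple bond is what matters remains open, since a saturated pentyl chain on the same oxygen would be needed to separate it from the other differences between these chains.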